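Swapping bromo for methyl on the phenyl ring

A few compounds are considered here, and "the series" means these few. Any claim that something is new, unique, unknown or untested is made for them only; others in the source may bear on it.

In a functional assay on A2780 cells (Homo sapiens) for antiproliferative activity, read by resazurin assay, with a stated time of 72 h (a higher number here means a weaker inhibitor, a lower number a stronger inhibitor), compound 3 `CN(Cc1ccccc1Br)C(=O)c1cc2c(Cc3ccccc3)n[nH]c2cc1O` gives 1200 nM. Compound 2 `CN(Cc1ccccc1)C(=O)c1cc2c(Cc3ccccc3)n[nH]c2cc1O` sits level with it at 980 nM. Compound 1 `CCCN(C)C(=O)c1cc2c(Cc3ccccc3)n[nH]c2cc1O` reads > 10000 nM, which is a limit of the assay and not a number.

Compound 4 `Cc1ccccc1CN(C)C(=O)c1cc2c(Cc3ccccc3)n[nH]c2cc1O` carries methyl in place of bromo on an aromatic carbon, ortho to a large group: methyl in place of bromo on an aromatic carbon. Two measured steps are large, an at least 10-fold lower number from compound 1 to compound 2 (1.00 log units; beyond the scatter) and an at least 8.3-fold lower number from compound 1 to compound 3 (0.92 log units; beyond the scatter), but they put a phenyl or 2-bromophenyl in place of ethyl and do not touch the spot that changes here. The measured step nearest that spot is a 1.2-fold higher number from compound 2 to compound 3 (0.09 log units; within the scatter), for bromo in place of hydrogen on an aromatic carbon. Compound 3 at 1200 nM is therefore the anchor, and no step beyond the scatter is expected in this assay. The expected change, a 1.1-fold lower number from compound 3 to compound 4 (0.04 log units; within the scatter), is small. Compound 4 is estimated at 1100 nM, with an expected range of 500 nM to 2400 nM.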

Compound 4, half-maximal inhibitory concentration: 4400 nM
Beside the measured number, compound 4's estimate is 4.0-fold (0.60 log units) below it; measured number outside the range, above it.
By their numbers in this assay, from the lowest: compounds 2 and 3 (each within the scatter of the next); then compound 4. At a limit, above all of these: compound 1.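

The earlier compounds shown here made this spot on the phenyl ring look tolerant, with bromo and hydrogen level, but methyl breaks that picture: in this assay there is a 3.7-fold higher number from compound 3 to compound 4 (0.56 log units; beyond the scatter) and a 4.5-fold higher number from compound 2 to compound 4 (0.65 log units; beyond the scatter). The swap exchanges one heavy atom for one heavy atom, so even a change this small at this spot can shift the reading beyond the scatter. The 2-methylphenyl group still improves on ethyl, with an at least 2.2-fold lower number from compound 1 to compound 4 (0.35 log units; beyond the scatter), but this step is only a minimum, as the value of compound 1 is a limit of the assay and not a number: the limit of > 10000 nM in this assay, at which 1 of the 4 values shown sits.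

These compounds do not tell why methyl raises the number here while bromo does not. From the compounds shown here alone, whether a chloro, a methoxy or an amine on the same ring carbon would read like compound 3 or like compound 4 stays open.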